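Compound 3 to its 3-hydroxyphenyl analogue, compound 4

This account rests on a few compounds, and the source may have more. Where it says the series, first, only, none or still open, it means among the compounds named here.

Of the compounds shown here, three sharing one core have been measured: compound 1 (`CC1(C)[C@H]2CC[C@]1(C)N(Cc1cn(-c3ccccc3C#N)nn1)C(=O)C2`), compound 2 (`COc1ccccc1-n1cc(CN2C(=O)C[C@@H]3CC[C@@]2(C)C3(C)C)nn1`) and compound 3 (`CC1(C)[C@H]2CC[C@]1(C)N(Cc1cn(-c3ccccc3)nn1)C(=O)C2`). In a functional assay on LoVo cells (Homo sapiens) for inhibition, read by MTT assay, with a stated time of 24 h (on this read-out higher numbers stand for weaker inhibition and lower numbers for stronger inhibition), compound 1 gives 140 nM, compound 2 gives 70 nM and compound 3 gives 50 nM. Compound 3 stands on the lower side of compound 1 by a margin beyond the scatter, while compound 3 and compound 2 lie within the scatter of each other.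

Compound 4 (`CC1(C)[C@H]2CC[C@]1(C)N(Cc1cn(-c3cccc(O)c3)nn1)C(=O)C2`) follows from compound 3 by one change: hydroxy in place of hydrogen on an aromatic carbon. This is hydroxy in place of hydrogen on an aromatic carbon, phenyl to 3-hydroxyphenyl.

Going by the values given here, three measured steps bear on it, all at a single substituent on the same aromatic ring. Hydrogen in place of cyano gives a 2.8-fold lower number from compound 1 to compound 3 (0.45 log units; beyond the scatter), a modest step beyond the scatter. Hydrogen in place of methoxy gives a 1.4-fold lower number from compound 2 to compound 3 (0.15 log units; within the scatter), and methoxy in place of cyano gives a 2.0-fold lower number from compound 1 to compound 2 (0.30 log units; within the scatter), both within the scatter. None of these compounds carries a hydroxy group, so the guide is indirect. Both substituted compounds have numbers no lower than the unsubstituted compound 3, which points to a small rise at most.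

The expected change in this assay is a 1.6-fold higher number from compound 3 to compound 4 (0.20 log units; within the scatter), a small upward step. For compound 4 the estimated value is 80 nM, with an expected range of 30 nM to 220 nM.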

Compound 4, half-maximal inhibitory concentration: 410 nM
For compound 4 the middle estimate is 5.1-fold (0.71 log units) below the measured one, and the stated range ends below it.
By their numbers in this assay, from the lowest: compounds 3, 2 and 1 (each within the scatter of the next, the first and the last beyond it); then compound 4.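

In this assay, going by these compounds alone, hydroxy in place of hydrogen on the aromatic ring gives an 8.2-fold higher number from compound 3 to compound 4 (0.91 log units; beyond the scatter) and so moves the number further than any substituent step among the earlier compounds; a single group at this place on the ring can clearly cost activity in these cells. Within the data shown here, the 3-hydroxyphenyl compound also ends above both other substituted compounds, with a 5.9-fold higher number from compound 2 to compound 4 (0.77 log units; beyond the scatter) and a 2.9-fold higher number from compound 1 to compound 4 (0.47 log units; beyond the scatter) as the two steps, so the narrow spread of the earlier compounds did not show the full range open to this ring. Nothing available on these compounds gives a reason for the rise.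

From the compounds shown here alone, what stays open is whether the rise follows the hydroxy group itself or its place on the ring, as the 2-methoxyphenyl and 2-cyanophenyl compounds differ from compound 4 in both; a 3-methoxyphenyl or a 2-hydroxyphenyl ring would separate the two. Also open, going by these compounds, is how an amine or a carboxylic acid would read at this same place on the ring.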